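From a Sulfonate Ester to an Amino Ester Side Chain

The source may hold more compounds than are shown below. What is called first, only, known or untested is meant among the compounds shown, and "the series" means these compounds.

Compound 1: `CS(=O)(=O)Oc1c(C(=O)NCc2ccc(F)cc2)nc(Br)c2cccnc12` — "not determined" (no result reported)
Compound 2: `CS(=O)(=O)NCCCN(c1nc(C(=O)NCc2ccc(F)cc2)c(O)c2ncccc12)S(C)(=O)=O` — > 20000 nM

Two compounds have been examined so far. Compound 1, `CS(=O)(=O)Oc1c(C(=O)NCc2ccc(F)cc2)nc(Br)c2cccnc12`, has no result in a functional assay on MCF7 cells (Homo sapiens) for cytotoxicity, read by MTT assay, with a stated time of 72 h; a lower number here means a stronger inhibitor, a higher number a weaker inhibitor: its entry reads "not determined" (no result reported). Compound 2, `CS(=O)(=O)NCCCN(c1nc(C(=O)NCc2ccc(F)cc2)c(O)c2ncccc12)S(C)(=O)=O`, gives in this assay only > 20000 nM, which is a limit of the assay rather than a number. That single value sits at the limit of > 20000 nM in this assay, at which 1 of the 2 values shown sits. Within the data shown here, compound 1 therefore stands nowhere on the scale yet, and no step between measured compounds can be drawn.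

Compound 3, `COC(=O)CNc1c(C(=O)NCc2ccc(F)cc2)nc(Br)c2cccnc12`, differs from compound 1 in one place: ((methoxycarbonyl)methyl)amino in place of (methylsulfonyl)oxy on an aromatic carbon. With no measured step to lean on, the size of the change in this assay cannot be judged; a shift beyond the scatter is possible in either direction, but nothing shown supports one side over the other. Compound 3 is expected to give about 15000 nM in this assay, roughly between 3000 nM and 60000 nM, with a real chance that only a limit is reported.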

Compound 3, half-maximal inhibitory concentration: > 10000 nM
Compound 3: a limit, no number; the forecaster's own chance of this, stated with the estimate: 50%; the middle value lies beyond the limit too.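

In this assay compound 3 gives > 10000 nM, which is a limit and not a number. Compound 1 offers no number for comparison, and no step can be read between compound 1 and compound 3. The compounds shown leave open which change to the shared core, if any, would give a measurable number in this assay.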